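The compounds below may be only part of what the source reports. "The series", "measured", "known", "first", "only" and "open" are said of these compounds alone.

Working notes on the series. Among the measured compounds shown here, compound 1, `CC(Oc1ccccc1-c1ccccc1)C1=NCCS1`, and compound 2, `CC(Oc1ccccc1-c1cccnc1)C1=NCCN1`, differ from each other in two places, so no single step is drawn between them. In a functional assay on CHO cells for agonist activity at Alpha-2C adrenergic receptor (Homo sapiens) (a higher number here means a larger maximal response, a lower number a smaller maximal response), compound 1 reaches only a limit of the assay, < 0.3, and no number. In this assay compound 2 gives 1, a full response against the reference agonist. For the measured compounds named here, compound 2 therefore holds the only number so far in this assay; the other value is a limit, as stated in the limit of < 0.3 in this assay, at which 1 of the 2 values shown sits.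

Compound 3, `Cc1cccc(-c2ccccc2OC(C)C2=NCCN2)c1`, is not yet measured. It differs from compound 2 by 3-methylphenyl in place of pyridin-3-yl on an aromatic carbon. The shared core of compound 2 is kept, and only the group on the aromatic carbon changes.

Going by the values given here, no measured step isolates this change, and the contrast between compound 1 and compound 2 cannot be read on it. The expectation for compound 3 in this assay is a step of a number 0.30 lower from compound 2 to compound 3 (beyond the scatter), downward and larger than the usual scatter, with a chance that the assay reports only a limit. Compound 3 is estimated at 0.7 in this assay, within 0.3 to 1.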

Compound 3, intrinsic activity: the largest response reached, as a fraction of the reference agonist's: 0.6
For compound 3 the middle estimate is 0.10 above the measured one, within the range that was stated.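

Among the compounds shown here, the step a number 0.40 lower from compound 2 to compound 3 (beyond the scatter) in this assay is the first change that can be read in one place, and it shows that with the shared core kept, the maximal response depends on the group on this aromatic carbon, ortho to a group of 8 heavy atoms. The full response of compound 2 does not survive the exchange of pyridin-3-yl for 3-methylphenyl, yet compound 3 still gives a measurable response of 0.6 rather than a limit of the assay. The exchange alters more than one feature at once, removing the ring nitrogen with its hydrogen-bond acceptor and adding a methyl group, and nothing shown gives a reason for the step or assigns it to either feature.

As far as these compounds go, it remains open whether the ring nitrogen or the methyl group accounts for the step, a question that a pyridin-3-yl ring carrying a methyl group on the shared core of compound 2 would address. Also open, from the compounds shown here alone, is how the response changes when the methyl group of compound 3 is replaced by a methoxy group or an amine.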